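A few compounds are considered here, and "the series" means these few. Any claim that something is new, unique, unknown or untested is made for them only; others in the source may bear on it.

The three measured compounds share one core and differ in the aryl group on the urea. Compound 1 `COc1cc(-c2nn(-c3cccc(NC(=O)Nc4ccc(Cl)c(Cl)c4)c3)cc2-c2ccncc2)ccc1Cl` gives in a functional assay on K562 cells (Homo sapiens) for inhibition, read by sulforhodamine B assay, with a stated time of 48 h (a lower number here means a stronger inhibitor of growth, a higher number a weaker inhibitor of growth), only a limit, > 50000 nM. Compound 2 `O=C(Nc1cccc(-n2cc(-c3ccncc3)c(-c3ccc(Cl)c(O)c3)n2)c1)Nc1ccc(Cl)c(Cl)c1` likewise gives only a limit, > 32500 nM. The step that the two limits leave unreadable from compound 1 to compound 2 is thus not readable. Compound 3 `O=C(Nc1cccc(-n2cc(-c3ccncc3)c(-c3ccc(Cl)c(O)c3)n2)c1)Nc1cc(C(F)(F)F)cc(C(F)(F)F)c1` gives a number, 3930 nM. Compound 4 `O=C(Nc1cccc(-n2cc(-c3ccncc3)c(-c3ccc(Cl)c(O)c3)n2)c1)Nc1ccc(Cl)c(C(F)(F)F)c1` differs from compound 2 by trifluoromethyl in place of chloro on an aromatic carbon. Among the measured compounds shown here, no measured step covers this change; the values of compound 2 and compound 3 show only that replacing both chloro groups with trifluoromethyl moves the compound from a limit to a readable number. A step toward stronger growth inhibition is therefore expected, an at least 3.2-fold lower number from compound 2 to compound 4 (0.51 log units; beyond the scatter), smaller than what compound 3 shows. Compound 4 is estimated at 10000 nM, between 3000 nM and 40000 nM.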

Compound 4, concentration for total growth inhibition: > 32500 nM
Compound 4: only a limit was reported; the forecaster's own chance of this, stated with the estimate: 30%; middle value at least 3.2-fold (0.51 log units) from the limit.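

Among the compounds shown here, compound 2 and compound 4 both give only a limit in this assay, and no step between them can be read. The compounds shown leave open whether trifluoromethyl in place of chloro changes growth inhibition at all.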